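Replacing the chlorobenzyl of compound 3 with a butyl chain

The compounds below may be only part of what the source reports. "The series", "measured", "known", "first", "only" and "open" are said of these compounds alone.

Of the compounds shown here, three sharing one core have been measured in an assay on isolated protein for inhibition of aldehyde dehydrogenase 1A1 (Homo sapiens), read by spectrophotometry, tested at 10 uM; on this read-out lower numbers stand for less inhibition and higher numbers for more inhibition at the one concentration tested (going by the name of the read-out). Compound 1 `CCn1c(CN2CCN(C(=O)C3CC3)CC2)nc2ccccc21` gives 20.8%. Compound 2 `Cc1ccc(Cn2c(CN3CCN(C(=O)C4CC4)CC3)nc3ccccc32)cc1` gives 51.5%, and compound 3 `O=C(C1CC1)N1CCN(Cc2nc3ccccc3n2Cc2ccc(Cl)cc2)CC1` gives 56.6%. Compound 3 stands highest of the three, but its gap to compound 2 is within the scatter, and only its gap to compound 1 is beyond it, as a number 35.8 percentage points higher from compound 1 to compound 3 (beyond the scatter) shows.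

Compound 4 `CCCCn1c(CN2CCN(C(=O)C3CC3)CC2)nc2ccccc21` is not yet measured. Against compound 3 it differs as propyl in place of 4-chlorophenyl on a saturated chain carbon bound to an aromatic nitrogen. Within the data shown here, the steps that bear on this are a number 35.8 percentage points higher from compound 1 to compound 3 (beyond the scatter) and a number 30.7 percentage points higher from compound 1 to compound 2 (beyond the scatter), both large and both in the direction from a short alkyl chain to an aryl group on the same carbon. The change from compound 3 to compound 4 runs the other way, from aryl to alkyl, so a drop beyond the scatter in this assay is expected, of roughly a number 28.6 percentage points lower from compound 3 to compound 4 (beyond the scatter). Among the measured compounds shown here, no measured step tells how propyl compares with methyl on that carbon, so the width of the range allows for that. Compound 4 is estimated at 28%, between 14% and 42%.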

Compound 4, a percentage reported as inhibition, at one concentration (the size of the read-out at that concentration, not a potency): 18.2%
Beside the measured number, compound 4's estimate is 9.8 percentage points above it; low and high end bracket the measured number.
By their numbers in this assay, from the lowest: compounds 4 and 1 (each within the scatter of the next); then compounds 2 and 3 (each within the scatter of the next).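

In this assay the longer alkyl chain of compound 4 cannot be told apart from the shorter one of compound 1, with a number 2.6 percentage points lower from compound 1 to compound 4 (within the scatter). Going from either aryl-bearing compound to the butyl chain gives large losses, with a number 38.4 percentage points lower from compound 3 to compound 4 (beyond the scatter) and a number 33.3 percentage points lower from compound 2 to compound 4 (beyond the scatter), so across these four compounds chain length alone does not replace the 4-chlorobenzyl or 4-methylbenzyl group at this position. Nothing measured here accounts for this difference between the aryl and alkyl groups.

The compounds shown leave open whether an unsubstituted benzyl group, with neither chloro nor methyl on its ring, would read like compound 2 and compound 3. They also leave open whether a phenethyl group or a butyl chain ending in an amine would read like compound 4 or like those two.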